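Octylsulfonamido benzoic acids: ethenyl-linked methoxyphenyl variant

A few compounds are considered here, and "the series" means these few. Any claim that something is new, unique, unknown or untested is made for them only; others in the source may bear on it.

Measured so far:
compound 1, `CCCCCCCCS(=O)(=O)Nc1cc(-c2ccc(-c3ccccc3)cc2)ccc1C(=O)O`: 13500 nM
compound 2, `CCCCCCCCS(=O)(=O)Nc1cc(-c2ccc(OC)cc2)ccc1C(=O)O`: 13300 nM

Both compounds were run in an assay on mitochondria (strain BALB/c) for inhibition of glycerol-3-phosphate acyltransferase 1, mitochondrial (Mus musculus), read by scintillation counting, with a stated time of 10 min; on this read-out lower numbers stand for stronger inhibition and higher numbers for weaker inhibition. Compound 1 gives 13500 nM and compound 2 gives 13300 nM; the two numbers sit together, and the step of a 1.0-fold lower number from compound 1 to compound 2 (0.01 log units; within the scatter) lies within the scatter, so compound 2 stands level with compound 1 rather than apart from it.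

Compound 3, `CCCCCCCCS(=O)(=O)Nc1cc(/C=C/c2ccc(OC)cc2)ccc1C(=O)O`, has not been measured. Its difference from compound 2 is 2-(4-methoxyphenyl)ethenyl in place of 4-methoxyphenyl on an aromatic carbon. Within the data shown here, no measured step involves an ethenyl link of this kind; the only step available, from compound 1 to compound 2, exchanged one group for another at the same aromatic carbon and produced no change beyond the scatter. That step gives no basis for expecting movement in either direction, so the expectation for compound 3 is a number near that of compound 2, with the step of a 1.1-fold lower number from compound 2 to compound 3 (0.04 log units; within the scatter) expected to fall within the scatter. Compound 3 is therefore estimated at 12000 nM, with a range of 4000 nM to 36000 nM.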

Compound 3, half-maximal inhibitory concentration: 38700 nM
Beside the measured number, compound 3's estimate is 3.2-fold (0.51 log units) below it, and the stated range ends below it.
By their numbers in this assay, from the lowest: compounds 2 and 1 (each within the scatter of the next); then compound 3.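

In this assay, the aromatic carbon para to a carboxy group proves sensitive to this change, with weaker inhibition (a 2.9-fold higher number from compound 2 to compound 3 (0.46 log units; beyond the scatter)) once the ethenyl link is added. The earlier exchange of methoxy for phenyl (a 1.0-fold lower number from compound 1 to compound 2 (0.01 log units; within the scatter)) had left the numbers within the scatter, so the series now holds its first step beyond it, though a modest one. 2-(4-Methoxyphenyl)ethenyl keeps the ring and the methoxy group of 4-methoxyphenyl, which ties this step to the added link, but nothing measured here explains the shift.

On these data alone, whether the step belongs to the double bond or to the longer link alone remains open, and a saturated ethyl link at the same carbon would separate the two. Also open, as far as these compounds go, is whether an amide link would behave like the ethenyl link, or a hydroxy group like the methoxy group on the ethenyl-linked ring.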